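The source may report more compounds than this note shows. Statements on the series, on what has been measured and on what is new or still open speak of the compounds shown alone.

Three compounds share one core and differ only in the group on a carbonyl carbon. Compound 1 `CCn1c(C(=O)Nc2cccc(C(F)(F)F)c2)ccc1C(CC)(CC)c1ccc(OCCC(O)(CC)CC)c(C)c1` gives 5900 nM in an assay on cells for agonist activity at vitamin D3 receptor (Homo sapiens), with a stated time of 96 h; a higher number here means that more compound is needed for the effect, a lower number that less compound is needed. Compound 2 `CCOC(=O)CN(C)C(=O)c1ccc(C(CC)(CC)c2ccc(OCCC(O)(CC)CC)c(C)c2)n1CC` gives 520 nM, a change of an 11-fold lower number from compound 1 to compound 2 (1.05 log units; beyond the scatter). Compound 3 `CCn1c(C(=O)N(C)CC(=O)O)ccc1C(CC)(CC)c1ccc(OCCC(O)(CC)CC)c(C)c1` gives 89 nM, the lowest of the three numbers, a change of a 66-fold lower number from compound 1 to compound 3 (1.82 log units; beyond the scatter) and, against compound 2, of a 5.8-fold lower number from compound 2 to compound 3 (0.77 log units; beyond the scatter). Compound 4 `CCC(C)C(CO)NC(=O)c1ccc(C(CC)(CC)c2ccc(OCCC(O)(CC)CC)c(C)c2)n1CC` carries a different group on that carbon: (1-(hydroxymethyl)-2-methylbutyl)amino in place of (carboxymethyl)(methyl)amino on a carbonyl carbon. Among the compounds with values here, the steps so far show that this position moves the numbers strongly, and that losing the acid of compound 3 cost a 5.8-fold lower number from compound 2 to compound 3 (0.77 log units; beyond the scatter) in reverse. Compound 4 is therefore expected to sit higher than compound 3, by an estimated 6.7-fold higher number from compound 3 to compound 4 (0.83 log units; beyond the scatter), at about 600 nM with a range of 150 nM to 3000 nM.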

Compound 4, half-maximal effective concentration: 450 nM
Compound 4: the middle estimate sits 1.3-fold (0.12 log units) above what was measured; low and high end bracket the measured number.
By their numbers in this assay, from the lowest: compound 3; then compounds 4 and 2 (each within the scatter of the next); then compound 1.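

Compound 4 shows that this carbonyl carbon does not need the carboxylic acid of compound 3 to stay well clear of the 3-(trifluoromethyl)phenyl amide: a 13-fold lower number from compound 1 to compound 4 (1.12 log units; beyond the scatter). A quite different group, (1-(hydroxymethyl)-2-methylbutyl)amino, matches the ester of compound 2, with a 1.2-fold lower number from compound 2 to compound 4 (0.06 log units; within the scatter). Within the data shown here, the acid still gives the lowest number so far, with a 5.1-fold higher number from compound 3 to compound 4 (0.70 log units; beyond the scatter).

Going by these compounds, whether the hydroxyl matters stays open, as would a plain 2-methylbutyl chain or an amine at this place. Nothing available here explains these differences.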